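Moving the Acid Around the Pyridine of a Receptor Agonist

A few compounds are considered here, and "the series" means these few. Any claim that something is new, unique, unknown or untested is made for them only; others in the source may bear on it.

Compound 1, `O=C(O)c1cncc(C2CC2c2ccc(OCc3c(-c4c(Cl)cccc4Cl)noc3C3CC3)cc2Cl)c1`: 103%
Compound 2, `O=C(O)CNC(=O)c1ccc(C2CC2c2ccc(OCc3c(-c4c(Cl)cccc4Cl)noc3C3CC3)cc2Cl)cc1`: 100%
Compound 3, `CS(=O)(=O)NC(=O)c1ccc([C@@H]2C[C@H]2c2ccc(OCc3c(-c4c(Cl)cccc4Cl)noc3C3CC3)cc2Cl)cc1`: 94%

All three compounds share one core and differ only in the acidic group at one end. They were tested in an assay on isolated protein for agonist activity at Bile acid receptor (Homo sapiens), read by FRET; a higher number here means a larger maximal response, a lower number a smaller maximal response. Compound 1 gives 103%, which is the top number of the three, yet the gap to compound 2 at 100% and the gap to compound 3 at 94% both lie within the usual scatter of this assay, so the three are best read as giving the same full response.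

The new compound 4, `O=C(O)c1ccc(C2CC2c2ccc(OCc3c(-c4c(Cl)cccc4Cl)noc3C3CC3)cc2Cl)cn1`, keeps everything of compound 1 except the position of the acid on the pyridine ring: 6-carboxypyridin-3-yl in place of 5-carboxypyridin-3-yl on a saturated ring carbon. The atoms are the same; only their arrangement changes.

Going by the values given here, no step between measured pairs has been worked out, so the expectation rests on the three values alone. Since each of them sits near the full reference response, the step from compound 1 to compound 4 in this assay is expected to be none beyond the scatter, that is a number 6 percentage points lower from compound 1 to compound 4 (within the scatter). Compound 4 is therefore estimated at 97%, in the range 80% to 110%.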

Compound 4, largest response reached (reported as efficacy), in percent of the reference or control that the assay uses: 101%
The estimate for compound 4 lay 4 percentage points below the measured number, within the range that was stated.
By their numbers in this assay, from the lowest: compounds 3, 2, 4 and 1 (each within the scatter of the next).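

Going by these compounds alone, the first pair to differ in only one place swaps 5-carboxypyridin-3-yl for 6-carboxypyridin-3-yl on a saturated ring carbon, and this gives a number 2 percentage points lower from compound 1 to compound 4 (within the scatter) in this assay for the two compounds. The earlier compounds shown here differ from one another across the whole acidic end, so they could not show what moving the carboxylic acid around the pyridine does on its own; for this one pair, the move leaves the maximal response unchanged within the scatter. Nothing measured here offers an explanation for this result.

The read-out records only the largest response reached, so this pair does not tell how much of either compound is needed to reach that response, and a difference of that kind could still exist between them. Also open, going by these compounds, is whether the same response would survive with an amine or a primary amide in place of the carboxylic acid on the pyridine, or with a plain benzene ring carrying the carboxylic acid directly in place of the pyridine.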